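Swapping a para iodo for a methyl on the shared core

A few compounds are considered here, and "the series" means these few. Any claim that something is new, unique, unknown or untested is made for them only; others in the source may bear on it.

For the measured compounds named here, compound 2 `CC(C)(C)N(NC(=O)c1ccc(I)cc1)C(=O)c1ccccc1Cl` has the lowest of the two numbers measured so far in an assay on cells for agonist activity at ecdysone receptor (Bombyx mori), read by a luciferase reporter, with a stated time of 24 h (a lower number here means that less compound is needed, a higher number that more compound is needed for the effect), giving 7.59 nM; compound 1 `CC(C)(C)N(NC(=O)c1ccccc1F)C(=O)c1ccccc1Cl` gives 51.3 nM. Going by the values given here, the one measured step, a 6.8-fold lower number from compound 1 to compound 2 (0.83 log units; beyond the scatter), shows that changing the substituent on this phenyl ring can move the number well beyond the scatter. Compound 3 `Cc1ccc(C(=O)NN(C(=O)c2ccccc2Cl)C(C)(C)C)cc1` carries methyl in place of iodo on an aromatic carbon. Among the compounds with values here, no measured step tests a para methyl, so the direction is uncertain. Compound 3 is expected to give 10 nM, within 3 nM to 35 nM, a step of a 1.3-fold higher number from compound 2 to compound 3 (0.12 log units; within the scatter) that is estimated to stay near the scatter.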

Compound 3, half-maximal effective concentration: 18.6 nM
The estimate for compound 3 lay 1.9-fold (0.27 log units) below the measured number; low and high end bracket the measured number.
By their numbers in this assay, from the lowest: compound 2; then compound 3; then compound 1.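

Methyl in place of iodo gives a 2.5-fold higher number from compound 2 to compound 3 (0.39 log units; beyond the scatter), so changing only the group at this one position moves the number beyond the scatter. The earlier step could not show this, as it changed both the group and where it sits on the ring. Compound 3 still keeps a lower number than the 2-fluorophenyl compound, with a 2.8-fold lower number from compound 1 to compound 3 (0.44 log units; beyond the scatter).

On these data alone, how an amine or a methoxy group at this position would compare remains open. No evidence at hand explains the gap between iodo and methyl.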